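Swapping a Fluorophenyl Ketone for a Nitrophenyl Ketone

The compounds below may be only part of what the source reports. "The series", "measured", "known", "first", "only" and "open" are said of these compounds alone.

Of the compounds shown here, three built on one shared core have been tested in a functional assay on HepG2 cells (Homo sapiens) for cytotoxicity, read by MTT assay, with a stated time of 48 h; on this read-out lower numbers stand for stronger inhibition and higher numbers for weaker inhibition. Compound 1 `COc1cc(-c2nnc3n2NC(c2cccs2)C(C(=O)c2ccc(F)cc2)S3)cc(OC)c1OC` gives 54200 nM in this assay. Compound 3 `COc1cc(-c2nnc3n2NC(c2cccs2)C(C(=O)c2ccc(Cl)cc2)S3)cc(OC)c1OC` gives 13200 nM. For the measured compounds named here, these two are separated by the only measured single change, a 4.1-fold lower number from compound 1 to compound 3 (0.61 log units; beyond the scatter). Compound 2 `COc1cc(-c2nnc3n2NC(c2ccco2)C(C(=O)c2ccccc2F)S3)cc(OC)c1OC` reaches only a limit of the assay, reported as > 100000 nM, so no number is known for it. Compound 2 therefore stands at the weak end of the measured set because of the limit of > 100000 nM in this assay, at which 1 of the 3 values shown sits.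

Compound 4 `COc1cc(-c2nnc3n2NC(c2ccco2)C(C(=O)c2ccc([N+](=O)[O-])cc2)S3)cc(OC)c1OC` differs from compound 2 in one place: 4-nitrophenyl in place of 2-fluorophenyl on a carbonyl carbon. Going by the values given here, the only measured step concerns a change of halogen on an aromatic carbon and was modest in size; it does not involve a nitro group, so it bears on the present change only loosely, and no other measured step touches a carbonyl-attached ring. Since compound 2 sits at the limit, any number found for compound 4 would mean a lower value, and the step expected is a modest one, an at least 1.6-fold lower number from compound 2 to compound 4 (0.22 log units; that floor lies within the scatter). Compound 4 is estimated at 60000 nM, with a range from 15000 nM to 150000 nM, while a fair chance remains that only a limit is reported again.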

Compound 4, half-maximal inhibitory concentration: 87800 nM
Compound 4: middle estimate off by 1.5-fold (0.17 log units), on the low side; the range from low to high includes it.
By their numbers in this assay, from the lowest: compound 3; then compounds 1 and 4 (each within the scatter of the next). At a limit, above all of these: compound 2.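

In this assay, changing the ring on the carbonyl carbon turns a limit into a real number, and the step is an at least 1.1-fold lower number from compound 2 to compound 4 (0.05 log units; that floor lies within the scatter). On these data alone, that floor is small, and the true size of the step stays unknown because compound 2 carries only a limit, not a number: the limit of > 100000 nM in this assay, at which 1 of the 4 values shown sits. For the compounds shown here, this is also the first look at a nitro-bearing ring at this position, with 4-nitrophenyl in place of 2-fluorophenyl, but a single swap cannot separate the arrival of the nitro group from the loss of the fluorine, and it gives no reason for the shift.

Compound 4 differs from compound 1 and compound 3 in more than one place, which leaves open how its nitro-bearing ring would compare with their fluoro and chloro rings if the rest of the molecule were held the same. Also open, as far as these compounds go, is what a plain phenyl, or a phenyl carrying an amine or a carboxylic acid, would give on the same carbonyl carbon.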